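The compounds below may be only part of what the source reports. "The series", "measured", "known", "first", "only" and "open" are said of these compounds alone.

Compound 1 `COc1ccc(/C=C2/S/C(=N/c3ccccc3)N(Cc3ccncc3)C2=O)cc1` and compound 2 `CN(C)c1ccc(/C=C2/S/C(=N/c3ccccc3)N(Cc3ccncc3)C2=O)cc1` share one core and differ in a single group. In a functional assay on HepG2 cells (Homo sapiens) for cytotoxicity, read by MTT assay, with a stated time of 48 h (a lower number here means a stronger inhibitor, a higher number a weaker inhibitor), compound 1 gives 19100 nM and compound 2 gives 52600 nM as the higher of the two numbers, which makes it the weaker inhibitor of this pair. Compound 3 `CC(C)c1ccc(/C=C2/S/C(=N/c3ccccc3)N(Cc3ccncc3)C2=O)cc1` changes the same group, and the difference isopropyl in place of dimethylamino on an aromatic carbon is isopropyl in place of dimethylamino on an aromatic carbon, para to a large group. For the measured compounds named here, one measured step bears on this, the modest 2.8-fold higher number from compound 1 to compound 2 (0.44 log units; beyond the scatter) that came with dimethylamino in place of methoxy. Going by the values given here, removing dimethylamino may undo part of that step, but no measured compound here carries isopropyl, so only a similarly modest move to a lower number is expected in this assay for this change. The estimated step is a 2.1-fold lower number from compound 2 to compound 3 (0.32 log units; beyond the scatter) in size. Compound 3 is expected at 25000 nM (estimated range 10000 nM to 60000 nM) in this assay.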

Compound 3, half-maximal inhibitory concentration: 32300 nM
Compound 3: middle estimate off by 1.3-fold (0.11 log units), on the low side, within the range that was stated.
By their numbers in this assay, from the lowest: compounds 1, 3 and 2 (each within the scatter of the next, the first and the last beyond it).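

In this assay, isopropyl in place of dimethylamino gives a 1.6-fold lower number from compound 2 to compound 3 (0.21 log units; within the scatter), and isopropyl in place of methoxy gives a 1.7-fold higher number from compound 1 to compound 3 (0.23 log units; within the scatter). Compound 3 therefore cannot be told apart from either compound 1 or compound 2, although those two differ from each other beyond the scatter, so swapping in a group with no hydrogen-bond acceptor at this position produces no readable change. Nothing available explains why these numbers fall as they do.

Still open, from the compounds shown here alone, is whether any group at this position can move the number well beyond the scatter, for example a carboxylic acid, a primary amine or a longer chain such as hexyl. A single fluorine atom here would also show whether a much smaller group keeps the number in this range.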